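The source may report more compounds than this note shows. Statements on the series, on what has been measured and on what is new or still open speak of the compounds shown alone.

In an ADME assay on HEK293 cells (Homo sapiens) for cytotoxicity, read by CCK-8 assay, with a stated time of 48 h (a lower number here means a stronger inhibitor, a higher number a weaker inhibitor), compound 2 `COc1ccc(/C=C\c2cc(OC)c(OC)c(OC)c2)cc1OCc1ccc(CNCCO)cc1` gives > 50000 nM, which is a limit of the assay and not a number. Compound 1 `COc1ccc(/C=C\c2cc(OC)c(OC)c(OC)c2)cc1OCc1ccc(CN2CCCC[C@H]2C(=O)O)cc1` gives > 50000 nM, and this too is only a limit. Both compounds therefore sit at the limit of > 50000 nM in this assay, at which 2 of the 2 values shown sit. Compound 3 `COc1ccc(/C=C\c2cc(OC)c(OC)c(OC)c2)cc1OCc1ccc(CNCCN(C)C)cc1` differs from compound 2 in one place: dimethylamino in place of hydroxy on a saturated chain carbon, two bonds along the chain from an amine nitrogen. In words, dimethylamino stands in place of hydroxy on a saturated chain carbon, two bonds along the chain from an amine nitrogen. Among the compounds with values here, the only measured step that bears on this change is a step that the two limits leave unreadable from compound 1 to compound 2, so it offers no size to carry over. With both known values at the limit, no clear movement is expected in this assay, and another limit is quite likely. The expected change is a number no higher from compound 2 to compound 3 (the limit leaves the size open), with no shift beyond the scatter anticipated. For compound 3 the estimate is 50000 nM, within an expected range of 15000 nM to 100000 nM.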

Compound 3, half-maximal inhibitory concentration: 39000 nM
Compound 3: the middle estimate sits 1.3-fold (0.11 log units) above what was measured, within the range that was stated.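

In this assay compound 3 gives 39000 nM, the only actual number among the compounds shown, so with dimethylamino in place of hydroxy on this saturated chain carbon, a value can be read for the first time in this series. Compound 2 gives > 50000 nM, which is a limit of the assay and not a number. The change in this position is an at least 1.2-fold lower number from compound 2 to compound 3 (0.10 log units; that floor lies within the scatter), and the change of the whole group on the chain carbon bound to the aromatic carbon is an at least 1.2-fold lower number from compound 1 to compound 3 (0.10 log units; that floor lies within the scatter), so neither floor shows a shift beyond the scatter.

As far as these compounds go, whether a longer chain between the two nitrogens, or a pyrrolidine or morpholine in place of dimethylamino, would move the value remains open. The true size of both steps also remains open because the other two compounds give only a limit: the limit of > 50000 nM in this assay, at which 2 of the 3 values shown sit.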